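This account rests on a few compounds, and the source may have more. Where it says the series, first, only, none or still open, it means among the compounds named here.

Two compounds have been measured in an in vitro assay on BTI-TN-5B1-4 cells for inhibition of Amine oxidase [flavin-containing] A (Homo sapiens), read by fluorescence; on this read-out higher numbers stand for weaker inhibition and lower numbers for stronger inhibition:

compound 1 `CC(C)CNC(=O)c1cc2ccc(OCc3ccccc3)cc2oc1=O`, 58600 nM
compound 2 `COc1cc(NC(=O)c2cc3ccc(OCc4ccccc4)cc3oc2=O)cc(OC)c1`, 52900 nM

Compound 2 stands alongside compound 1: the step of a 1.1-fold lower number from compound 1 to compound 2 (0.04 log units; within the scatter) lies within the scatter, so the two cannot be told apart. Compound 3 `COc1cc(NC(=O)c2cc3ccc(OCc4ccc(F)cc4)cc3oc2=O)cc(OC)c1` has not yet been measured. It differs from compound 2 by fluoro in place of hydrogen on an aromatic carbon. Going by the values given here, no measured step concerns this kind of change; the only known step, a 1.1-fold lower number from compound 1 to compound 2 (0.04 log units; within the scatter), touches a different part of the molecule and left the number essentially unchanged. The step of a 1.1-fold lower number from compound 2 to compound 3 (0.02 log units; within the scatter) is therefore expected to stay within the scatter, with no clear direction. For compound 3 the estimate is 50000 nM, ranging from 20000 nM to 130000 nM.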

Compound 3, half-maximal inhibitory concentration: 52600 nM
Estimate against measurement, compound 3: 1.1-fold (0.02 log units) below; the measured number falls inside the stated range.
By their numbers in this assay, from the lowest: compounds 3, 2 and 1 (each within the scatter of the next).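

Fluoro in place of hydrogen on the benzyl ring, the change from benzyl to 4-fluorobenzyl, gives a 1.0-fold lower number from compound 2 to compound 3 (0.00 log units; within the scatter) and so leaves the two compounds indistinguishable. Going by these compounds alone, this is the first look at the far end of the benzyloxy group, as the earlier step concerned only the amide nitrogen. No other data bear on this result. Going by these compounds, whether this spot responds to anything larger stays open, for instance an amine or a carboxylic acid in place of the fluoro.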